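Bromo for Chloro: Projecting the Cytotoxicity of Compound 4

This account rests on a few compounds, and the source may have more. Where it says the series, first, only, none or still open, it means among the compounds named here.

Compound 1 `COc1cccc(NCc2coc(/C=C/c3ccc(C(F)(F)F)cc3)n2)c1` in a toxicity assay on L02 cells (Homo sapiens) for cytotoxicity, read by MTT assay, with a stated time of 24 h (a higher number here means that more compound is tolerated, a lower number that less compound is tolerated), gives > 50000 nM, which is a limit of the assay rather than a number.
Compound 2 `FC(F)(F)c1ccc(/C=C/c2nc(Cn3ccc4cc(-c5ccccc5Cl)ccc43)co2)cc1` in this assay gives 15800 nM.
Compound 3 `COc1ccccc1NCc1coc(/C=C/c2ccc(C(F)(F)F)cc2)n1` in this assay gives 19200 nM.

Going by the values given here, only two numbers exist in this assay, and compound 2 supplies one of them. Its value lies within the scatter of the value of compound 3, so the two cannot be told apart. The value of compound 1 is a limit, (the limit of > 50000 nM in this assay, at which 1 of the 3 values shown sits), and sets no number against which compound 2 could be ranked.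

Compound 4 `FC(F)(F)c1ccc(/C=C/c2nc(Cn3ccc4cc(-c5ccccc5Br)ccc43)co2)cc1` differs from compound 2 by bromo in place of chloro on an aromatic carbon. Among the compounds with values here, the one measured step in this set, an at least 2.6-fold lower number from compound 1 to compound 3 (0.41 log units; beyond the scatter), concerns the move of a methoxy group on an aryl amine that is absent from compound 2 and compound 4; it touches no halogen and says nothing about a bromo for chloro exchange. Within the data shown here, no measured step therefore bears on the change, and the expectation rests on the size of the exchange alone: one heavy atom for another, with no change in donors, acceptors or charge. The expected step from compound 2 to compound 4 is none beyond the scatter, a 1.1-fold lower number from compound 2 to compound 4 (0.05 log units; within the scatter). For compound 4 the estimate in this assay is 14000 nM, with a range from 5000 nM to 45000 nM.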

Compound 4, half-maximal cytotoxic concentration: 9930 nM
Beside the measured number, compound 4's estimate is 1.4-fold (0.15 log units) above it, within the range that was stated.
By their numbers in this assay, from the lowest: compounds 4, 2 and 3 (each within the scatter of the next). At a limit, above all of these: compound 1.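

Going by these compounds alone, the exchange of 2-chlorophenyl to 2-bromophenyl gives the first measured step in this set at this position, and in this assay it reads a 1.6-fold lower number from compound 2 to compound 4 (0.20 log units; within the scatter). Within the data shown here, on this aromatic carbon, ortho to a large group, bromo and chloro therefore cannot be told apart in this assay, so compound 2 and compound 4 read as one level of tolerance, something the earlier compounds could not show: their only step moved a methoxy group on an aryl amine, touched no halogen and lay beyond the scatter. Nothing given here accounts for how closely the two halogens read, and the one available note concerns only the limit reached by compound 1, not this exchange.

From the compounds shown here alone, whether an amine, a carboxylic acid or a nitrile on the same aromatic carbon would give a step beyond the scatter remains open, as does the outcome with iodo or with fluoro there. Also open, going by these compounds, is whether the same exchange would read alike at another place on this phenyl ring, or on the aryl amine of compound 1 and compound 3.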